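Swapping pyridin-3-yl for pyridin-4-yl on compound 2

A few compounds are considered here, and "the series" means these few. Any claim that something is new, unique, unknown or untested is made for them only; others in the source may bear on it.

In a functional assay on SMMC-7721 cells (Homo sapiens) for cytotoxicity, read by MTT assay, with a stated time of 24 h (on this read-out lower numbers stand for stronger inhibition and higher numbers for weaker inhibition), compound 1 `O=C1/C(=C/c2cccnc2)CN(S(=O)(=O)c2ccc([N+](=O)[O-])cc2)C/C1=C\c1ccccc1C(F)(F)F` gives 15900 nM, compound 3 `CC(=O)Nc1ccc(S(=O)(=O)N2C/C(=C\c3cccnc3)C(=O)/C(=C/c3ccccc3C(F)(F)F)C2)cc1` gives 9830 nM and compound 2 `O=C1/C(=C/c2cccnc2)CN(S(=O)(=O)c2ccc(F)cc2)C/C1=C\c1ccccc1C(F)(F)F` gives 6390 nM. Among the compounds with values here, compound 2 is clearly separated from only one neighbour, as a 2.5-fold lower number from compound 1 to compound 2 (0.40 log units; beyond the scatter) shows, while a 1.5-fold higher number from compound 2 to compound 3 (0.19 log units; within the scatter) does not separate those two. The remaining step is a 1.6-fold lower number from compound 1 to compound 3 (0.21 log units; within the scatter).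

Compound 4 `O=C1/C(=C/c2ccncc2)CN(S(=O)(=O)c2ccc(F)cc2)C/C1=C\c1ccccc1C(F)(F)F` has the same atoms as compound 2, joined differently, with pyridin-4-yl in place of pyridin-3-yl on a double-bonded chain carbon bound to a double-bonded ring carbon.

Within the data shown here, none of the measured steps touches that group. All three exchange nitro, fluoro and acetamido on an aromatic carbon elsewhere, so they indicate only the general size of a single change, and even the largest is modest. They offer no direction for this swap. In this assay the expected step is therefore a 1.1-fold higher number from compound 2 to compound 4 (0.03 log units; within the scatter), with nothing anticipated beyond the scatter. The estimate for compound 4 is 6800 nM, with an expected range of 2800 nM to 16000 nM.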

Compound 4, half-maximal inhibitory concentration: 9270 nM
Compound 4: middle estimate off by 1.4-fold (0.13 log units), on the low side; low and high end bracket the measured number.
By their numbers in this assay, from the lowest: compounds 2, 4, 3 and 1 (each within the scatter of the next, the first and the last beyond it).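

Within the data shown here, exchanging pyridin-3-yl for pyridin-4-yl on a double-bonded chain carbon bound to a double-bonded ring carbon gives the only step at this place, and in this assay it reads a 1.5-fold higher number from compound 2 to compound 4 (0.16 log units; within the scatter) and so stays within the usual variation between repeats. For this pair, therefore, the two groups, which carry the same atoms, cannot be told apart by this read-out, and the swap costs nothing that can be distinguished from scatter. Nothing measured here accounts for the size of this step.

Going by these compounds, whether a plain phenyl or a pyridin-2-yl group at the same place would give a clearly different number remains open. So does whether this swap would behave the same way with nitro or acetamido on the other aromatic ring instead of fluoro.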